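The compounds below may be only part of what the source reports. "The series", "measured", "known", "first", "only" and "open" are said of these compounds alone.

Series sharing one core, differing on a saturated chain carbon bound to a carbonyl carbon. Compound 1 `NS(=O)(=O)CC(=O)NCCSc1nonc1/C(=N/O)Nc1ccc(F)c(C(F)F)c1` gives 2.77 h in an ADME assay on microsomes from liver (Homo sapiens) for metabolic stability; on this read-out higher numbers stand for a longer-lived compound and lower numbers for a shorter-lived compound; compound 2 `N#CCC(=O)NCCSc1nonc1/C(=N/O)Nc1ccc(F)c(C(F)F)c1` gives 2.77 h in this assay, and no change at the digits printed from compound 1 to compound 2 (within the scatter). Compound 3 `CC(C)(O)CC(=O)NCCSc1nonc1/C(=N/O)Nc1ccc(F)c(C(F)F)c1` gives 0.937 h in this assay, the lowest of the three numbers: a 3.0-fold lower number from compound 1 to compound 3 (0.47 log units; beyond the scatter) and a 3.0-fold lower number from compound 2 to compound 3 (0.47 log units; beyond the scatter).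

Compound 4 `CS(=O)(=O)CC(=O)NCCSc1nonc1/C(=N/O)Nc1ccc(F)c(C(F)F)c1` is next: methylsulfonyl in place of 1-hydroxy-1-methylethyl on a saturated chain carbon bound to a carbonyl carbon. Within the data shown here, the steps that bear on it are the two into compound 3, both modest and both in the same direction, and the group entering compound 4 is nearest to the sulfamoyl of compound 1. In this assay a modest rise back toward compound 1 is therefore expected for compound 4, roughly reversing a 3.0-fold lower number from compound 1 to compound 3 (0.47 log units; beyond the scatter); the estimated step is a 2.7-fold higher number from compound 3 to compound 4 (0.43 log units; beyond the scatter). For compound 4 the estimate is 2.5 h, with a range from 1.2 h to 5 h.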

Compound 4, half-life: 1.27 h
Compound 4: the middle estimate sits 2.0-fold (0.29 log units) above what was measured; measured number inside the range.
By their numbers in this assay, from the lowest: compounds 3 and 4 (each within the scatter of the next); then compounds 1 and 2 (each within the scatter of the next).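

In this assay, the sulfonyl group alone does not keep the number of compound 1: methyl in place of amino on the sulfonyl sulfur gives a modest drop (a 2.2-fold lower number from compound 1 to compound 4 (0.34 log units; beyond the scatter)), and methylsulfonyl in place of cyano gives a drop of the same printed size (a 2.2-fold lower number from compound 2 to compound 4 (0.34 log units; beyond the scatter)). Methylsulfonyl and 1-hydroxy-1-methylethyl are not separated at this saturated chain carbon (a 1.4-fold higher number from compound 3 to compound 4 (0.13 log units; within the scatter)). Nothing at hand explains these steps. Open, on these data alone, is whether a carboxylic acid, a primary amine or a longer chain here would sit with compounds 1 and 2 or with compounds 3 and 4.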